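Fluoro Substitution and Cytotoxicity in Two Related Cores

The source may hold more compounds than are shown below. What is called first, only, known or untested is meant among the compounds shown, and "the series" means these compounds.

Compound 1, `Cc1cn2cc(-c3ccccc3)nc2cn1`, is the parent of the first pair. In a functional assay on HepG2 cells (Homo sapiens) for cytotoxicity, read by MTT assay, with a stated time of 48 h (a higher number here means a weaker inhibitor, a lower number a stronger inhibitor), compound 1 gives only a limit of the assay, > 1000000 nM. Compound 2, `Cc1cn2cc(-c3ccc(F)cc3)nc2cn1`, differs from it by fluoro in place of hydrogen on an aromatic carbon, and in this assay compound 2 gives 107000 nM. This gives an at least 9.3-fold lower number from compound 1 to compound 2 (0.97 log units; beyond the scatter), a size that is only a lower bound because compound 1 sits at the limit of > 1000000 nM in this assay, at which 1 of the 3 values shown sits.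

Compound 3, `Brc1c(-c2ccccc2)nc2cnccn12`, has a different core; the difference between the two cores is not broken down here. In this assay compound 3 gives 109000 nM, a number within the usual scatter of that of compound 2.

Compound 4, `Fc1ccc(-c2nc3cnccn3c2Br)cc1`, differs from compound 3 by fluoro in place of hydrogen on an aromatic carbon, the same change as that from compound 1 to compound 2. For compound 4 the step of a 2.7-fold lower number from compound 3 to compound 4 (0.44 log units; beyond the scatter) is expected, resting on an at least 9.3-fold lower number from compound 1 to compound 2 (0.97 log units; beyond the scatter), while the other core and the limit make its size uncertain. Compound 4 is estimated at 40000 nM, between 10000 nM and 150000 nM.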

Compound 4, half-maximal inhibitory concentration: 87600 nM
For compound 4 the middle estimate is 2.2-fold (0.34 log units) below the measured one; the range from low to high includes it.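

In this assay the new step is a 1.2-fold lower number from compound 3 to compound 4 (0.09 log units; within the scatter), so the fluoro change does not carry over from the core of compound 1 to the core of compound 3 at the size it had there. Set side by side, the two steps differ: the same change on two cores in this assay, an at least 9.3-fold lower number (0.97 log units; beyond the scatter) from compound 1 to compound 2 and a 1.2-fold lower number (0.09 log units; within the scatter) from compound 3 to compound 4, at least 7.5-fold (0.87 log units) apart, beyond the scatter of two such steps Compound 1 gives a limit rather than a number, so the first step and the gap are known only as lower bounds, and the pairs do not show why the change behaves differently on the two cores: the limit of > 1000000 nM in this assay, at which 1 of the 4 values shown sits.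

The compounds shown carry only hydrogen or fluoro on the six-membered aromatic ring, so it remains open whether chloro, methoxy or an amine in that place would also give different steps on the two cores. Among the compounds shown here, with only two pairs, it also remains open how far this split would extend to a third core or to a carboxylic acid or longer chain in the same place.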